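This account rests on a few compounds, and the source may have more. Where it says the series, first, only, none or still open, it means among the compounds named here.

Measured compounds in a functional assay on SW480 cells (Homo sapiens) for cytotoxicity, read by MTT assay, with a stated time of 4 days; a lower number here means a stronger inhibitor, a higher number a weaker inhibitor:
compound 1 `Cc1ccc(S(=O)(=O)Oc2ccc3c(c2C)[C@H](Cn2cc(-c4ccccc4)nn2)[C@@]24CC(=O)[C@@](C)(CC[C@@H]32)C4)cc1` — compound 1 gives > 20000 nM, a limit of the assay.
compound 2 `Cc1ccc(S(=O)(=O)Oc2ccc3c(c2C)[C@H](Cn2cc(-c4ccccn4)nn2)[C@@]24CC(=O)[C@@](C)(CC[C@@H]32)C4)cc1` — compound 2 gives > 20000 nM, a limit of the assay.
compound 3 `Cc1ccc(S(=O)(=O)Oc2ccc3c(c2C)[C@H](Cn2cc(-c4ccc(Br)cc4)nn2)[C@@]24CC(=O)[C@@](C)(CC[C@@H]32)C4)cc1` — compound 3 gives > 20000 nM, a limit of the assay.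

Compound 3 stands nowhere on a numeric scale: its value is a limit, and the other two values are limits as well, all three at the limit of > 20000 nM in this assay, at which 3 of the 3 values shown sit. For the measured compounds named here, no step between the measured compounds can be read: a step that the two limits leave unreadable from compound 1 to compound 2, a step that the two limits leave unreadable from compound 1 to compound 3, a step that the two limits leave unreadable from compound 2 to compound 3.

Compound 4 `Cc1ccc(S(=O)(=O)Oc2ccc3c(c2C)[C@H](Cn2cc(-c4ccc(C(F)(F)F)cc4)nn2)[C@@]24CC(=O)[C@@](C)(CC[C@@H]32)C4)cc1` has not been measured. It differs from compound 3 by trifluoromethyl in place of bromo on an aromatic carbon. The two steps that bear on this change, a step that the two limits leave unreadable from compound 1 to compound 3 and a step that the two limits leave unreadable from compound 2 to compound 3, give no readable size, since both ends of each sit at the limit of > 20000 nM in this assay, at which 3 of the 3 values shown sit. Going by the values given here, nothing among the measured compounds supports a move out of the limit region, so in this assay the step that the limit leaves unreadable from compound 3 to compound 4 is expected, with no direction claimable beyond the scatter. Compound 4 is estimated at 30000 nM, within 8000 nM to 120000 nM, and is most likely to be reported again only as a limit.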

Compound 4, half-maximal inhibitory concentration: > 20000 nM
Compound 4 was reported as a limit (the forecaster's own chance of this, stated with the estimate: 80%); the middle value lies beyond the limit too.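

For the compounds shown here, no step linking compound 4 with compound 1, compound 2 or compound 3 can be read, because all four compounds give the same limit: the limit of > 20000 nM in this assay, at which 4 of the 4 values shown sit. The compounds shown leave open how these four rank and which change to the shared core, if any, would give a numeric value.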